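A Longer Chain to the Same Ring

The source may hold more compounds than are shown below. What is called first, only, known or untested is meant among the compounds shown, and "the series" means these compounds.

In an assay on microsomes from liver for inhibition of sterol O-acyltransferase 1 (Rattus norvegicus) (a higher number here means a weaker inhibitor, a lower number a stronger inhibitor), compound 3 `c1ccc(-c2nc(SCC3OCCCO3)[nH]c2-c2ccccc2)cc1` gives 180 nM, while compound 1 `CC1=CC(=O)OC(CSc2nc(-c3ccccc3)c(-c3ccccc3)[nH]2)C1` gives 200 nM and compound 2 `CC1(C)CC(=O)OC(CSc2nc(-c3ccccc3)c(-c3ccccc3)[nH]2)C1` gives 100 nM. The steps of a 1.1-fold lower number from compound 1 to compound 3 (0.05 log units; within the scatter) and a 1.8-fold higher number from compound 2 to compound 3 (0.26 log units; within the scatter) both lie within the scatter, as does a 2.0-fold lower number from compound 1 to compound 2 (0.30 log units; within the scatter), so the three values cannot be told apart. Compound 4 `c1ccc(-c2nc(SCCC3OCCCO3)[nH]c2-c2ccccc2)cc1` differs from compound 3 by a group of 7 heavy atoms (5 carbon, 2 oxygen; one six-membered non-aromatic ring with 2 hetero atoms) in place of a group of 6 heavy atoms (4 carbon, 2 oxygen; one six-membered non-aromatic ring with 2 hetero atoms), on a saturated chain carbon bound to a sulfur. Every measured step in this set exchanged a ring on a saturated chain carbon bound to a sulfur and none moved the value beyond the scatter, so lengthening the chain is expected to leave this assay unchanged beyond the scatter as well. For compound 4 the estimate is 180 nM, between 90 nM and 360 nM, which means an expected step of no change at the digits printed from compound 3 to compound 4 (within the scatter).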

Compound 4, half-maximal inhibitory concentration: 730 nM
Estimate against measurement, compound 4: 4.1-fold (0.61 log units) below, outside the stated range (above it).
By their numbers in this assay, from the lowest: compounds 2, 3 and 1 (each within the scatter of the next); then compound 4.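

In this assay, this position now shows a real response: with the same six-membered ring carrying two hetero atoms, the longer chain gives a 4.1-fold higher number from compound 3 to compound 4 (0.61 log units; beyond the scatter). Among these compounds, the other two comparisons agree, with a 7.3-fold higher number from compound 2 to compound 4 (0.86 log units; beyond the scatter) and a 3.7-fold higher number from compound 1 to compound 4 (0.56 log units; beyond the scatter), whereas no step among the earlier compounds left the scatter. Nothing available explains this rise. On these data alone, whether a still longer chain would raise the number further remains open. So does whether an amine in place of the ring would hold at this longer chain length.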